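Benzyl for Dichlorophenyl in a Steroid Reductase Inhibitor Series

A few compounds are considered here, and "the series" means these few. Any claim that something is new, unique, unknown or untested is made for them only; others in the source may bear on it.

In an assay on CHO cells for inhibition of 3-oxo-5-alpha-steroid 4-dehydrogenase 2 (Homo sapiens) (on this read-out higher numbers stand for weaker inhibition and lower numbers for stronger inhibition), compound 1 `O=C(O)c1ccc(C(=O)c2ccc(C(=O)c3ccc(O)cc3)cc2)cc1` gives 22 nM and compound 2 `O=C(O)c1ccc(C(=O)c2ccc(-c3ccc(Cl)cc3Cl)cc2)cc1` gives 85 nM.

Compound 2 thus has the higher of the two numbers, and its gap to compound 1 lies beyond the scatter. Compound 3 `Cc1ccc(Cc2ccc(C(=O)c3ccc(C(=O)O)cc3)cc2)cc1` differs from compound 2 by 4-methylbenzyl in place of 2,4-dichlorophenyl on an aromatic carbon. Among the compounds with values here, no step between measured compounds bears on this change, so its direction is open. The step of a 1.2-fold lower number from compound 2 to compound 3 (0.08 log units; within the scatter) is expected to stay close to the scatter, with no clear gain or loss. Compound 3 is therefore estimated at 70 nM, within a range from 18 nM to 280 nM.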

Compound 3, inhibition constant: 15 nM
For compound 3 the middle estimate is 4.7-fold (0.67 log units) above the measured one, and the stated range ends above it.
By their numbers in this assay, from the lowest: compounds 3 and 1 (each within the scatter of the next); then compound 2.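

At this position, on an aromatic carbon para to a large group, 4-methylbenzyl in place of 2,4-dichlorophenyl brings a 5.7-fold lower number from compound 2 to compound 3 (0.75 log units; beyond the scatter) in this assay. The position therefore responds to this exchange, although the step lies beyond the scatter only modestly. Both groups carry one six-membered aromatic ring of carbon only and no hydrogen-bond donors or acceptors, so the step comes without a change in those counts.

From the compounds shown here alone, what a plain benzyl or a plain phenyl group would give here stays open, leaving the step undivided between the methylene link and the ring substituents. Nothing measured here explains the step.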